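Removing the trifluoromethyl group from compound 1

The source may hold more compounds than are shown below. What is called first, only, known or untested is meant among the compounds shown, and "the series" means these compounds.

Compound 1 `FC(F)(F)c1ccc(COc2ccc(Nc3ncnc4cc5c(cc34)OCCOCCOCCOCCO5)cc2)cc1` gives 3340 nM
Compound 2 `O=[N+]([O-])c1ccc(COc2cccc(Nc3ncnc4cc5c(cc34)OCCOCCOCCOCCO5)c2)cc1` gives 9820 nM
Compound 3 `c1ccc(COc2cccc(Nc3ncnc4cc5c(cc34)OCCOCCO5)c2)cc1` gives > 100000 nM

In a functional assay on HepG2 cells (Homo sapiens) for antiproliferative activity, read by MTT assay, with a stated time of 72 h (a higher number here means a weaker inhibitor, a lower number a stronger inhibitor), compound 1 gives 3340 nM and so holds the lowest of the two actual numbers. Compound 2 gives 9820 nM and lies beyond the scatter above it. Compound 3 gives > 100000 nM as its result, which is a limit of the assay and not a number.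

Compound 4 `c1ccc(COc2ccc(Nc3ncnc4cc5c(cc34)OCCOCCOCCOCCO5)cc2)cc1` has not yet been measured. It is compound 1 with hydrogen in place of trifluoromethyl on an aromatic carbon, para to a large group, so that 4-(trifluoromethyl)benzyl becomes benzyl (hydrogen in place of trifluoromethyl on an aromatic carbon). Among the compounds with values here, no measured pair of compounds shows this change on its own, so the data give no direct size for it.

Compound 2, at 9820 nM in this assay, differs from compound 1 in more than one place, yet it shares the core of compound 1 and is the nearest number available. On that slim basis, a modest move toward a higher number is expected, ending not far beyond the scatter. The estimated move is a 1.8-fold higher number from compound 1 to compound 4 (0.25 log units; within the scatter) in this assay, and it remains uncertain. Compound 4 is estimated at 6000 nM (expected range 2000 nM to 20000 nM).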

Compound 4, half-maximal inhibitory concentration: 11900 nM
Compound 4: the middle estimate sits 2.0-fold (0.30 log units) below what was measured, and the stated range covers the measured number.
By their numbers in this assay, from the lowest: compound 1; then compounds 2 and 4 (each within the scatter of the next). At a limit, above all of these: compound 3.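

In this assay, replacing trifluoromethyl with hydrogen on an aromatic carbon, para to a large group, gives a 3.6-fold higher number from compound 1 to compound 4 (0.55 log units; beyond the scatter), and everything else in the molecule stays the same. Within the data shown here, compound 1 had no partner differing from it in one place until now, so this is the first direct reading of what the trifluoromethyl group contributes at this position. The step lies beyond the usual scatter but is modest, and compound 4 still gives a real number and not an assay limit, so the 4-(trifluoromethyl)benzyl group is not essential for a measurable effect in these cells. The data shown give no explanation for the size of this step.

From the compounds shown here alone, only trifluoromethyl and hydrogen have been compared directly at this position, so it remains open where a chlorine atom, a methoxy group or a nitrile in the same place would fall relative to compound 1 and compound 4. Whether the same change would give a similar step on a different core, or in a different cell line, also cannot be read from these compounds.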